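Adding an amino group to compound 2

A few compounds are considered here, and "the series" means these few. Any claim that something is new, unique, unknown or untested is made for them only; others in the source may bear on it.

Measured so far in a functional assay on MDA-MB-231 cells (Homo sapiens) for inhibition, read by MTT assay, with a stated time of 48 h; a lower number here means a stronger inhibitor, a higher number a weaker inhibitor:
Compound 1 `COc1cc(-c2nccn3cc(-c4ccc(F)cc4)nc23)cc(OC)c1OC` gives 401 nM
Compound 2 `COc1cc(-c2nccn3cc(-c4ccccc4)nc23)cc(OC)c1OC` gives 364 nM

On these numbers, compound 2 cannot be told apart from compound 1. Within the data shown here, the only measured step is a 1.1-fold lower number from compound 1 to compound 2 (0.04 log units; within the scatter), and it replaces fluoro with hydrogen on an aromatic carbon.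

Compound 3 `COc1cc(-c2nccn3cc(-c4ccc(N)cc4)nc23)cc(OC)c1OC` is still unmeasured. It changes phenyl to 4-aminophenyl, with amino in place of hydrogen on an aromatic carbon. Among the measured compounds shown here, the step from fluoro to hydrogen is the only guide, and a weak one, since no compound with an amino group has been measured. Given the small size of a 1.1-fold lower number from compound 1 to compound 2 (0.04 log units; within the scatter), no change beyond the scatter is expected in this assay, and neither direction is favoured. For compound 3 the estimated value is 300 nM, with an expected range of 90 nM to 1000 nM. This estimate means an expected 1.2-fold lower number from compound 2 to compound 3 (0.08 log units; within the scatter).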

Compound 3, half-maximal inhibitory concentration: 294 nM
The estimate for compound 3 lay 1.0-fold (0.01 log units) above the measured number, within the range that was stated.
By their numbers in this assay, from the lowest: compounds 3, 2 and 1 (each within the scatter of the next).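

In this assay, placing amino on this aromatic carbon gives a 1.2-fold lower number from compound 2 to compound 3 (0.09 log units; within the scatter), and amino in place of fluoro gives a 1.4-fold lower number from compound 1 to compound 3 (0.13 log units; within the scatter). This position, para to a large group, has now carried hydrogen, fluoro and amino, and amino brings a hydrogen-bond donor and a hydrogen-bond acceptor, yet the assay does not separate these compounds. Across these three groups, then, the choice of group here makes no difference that can be read beyond the scatter.

Going by these compounds, whether that holds for a carboxylic acid, an amide or a longer chain at the same position remains open. It is also open whether other cell lines would separate these compounds, and nothing shown here explains why the three read alike.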